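Amino Substitution on a Thiophene-Bearing Nucleoside Core

This account rests on a few compounds, and the source may have more. Where it says the series, first, only, none or still open, it means among the compounds named here.

Of the compounds shown here, three sharing one nucleoside core have been tested in a functional assay on CEM-DNR-bulk cells (Homo sapiens), read by MTT assay, with a stated time of 72 h; a lower number here means a stronger inhibitor, a higher number a weaker inhibitor. Compound 1 `COc1ncnc2c1c(-c1ccsc1)cn2[C@@H]1O[C@H](CO)[C@@H](O)[C@H]1O` gives 7640 nM in this assay. Compound 2 `COc1nc(N)nc2c1c(-c1ccsc1)cn2[C@@H]1O[C@H](CO)[C@@H](O)[C@H]1O` reaches only a limit of the assay, > 20000 nM, rather than a number. Compound 3 `COc1ncnc2c1c(-c1cccs1)cn2[C@@H]1O[C@H](CO)[C@@H](O)[C@H]1O` gives 12100 nM in this assay.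

Two changes connect these structures. Between compound 1 and compound 2 the change is amino in place of hydrogen on an aromatic carbon, and it produced an at least 2.6-fold higher number from compound 1 to compound 2 (0.41 log units; beyond the scatter). Between compound 1 and compound 3 the cores differ by thiophen-2-yl in place of thiophen-3-yl on an aromatic carbon, which produced a 1.6-fold higher number from compound 1 to compound 3 (0.20 log units; within the scatter); these two values are within the scatter of each other.

Compound 4 `COc1nc(N)nc2c1c(-c1cccs1)cn2[C@@H]1O[C@H](CO)[C@@H](O)[C@H]1O` has not been measured. It differs from compound 3 by amino in place of hydrogen on an aromatic carbon. Within the data shown here, this is the same change as the one from compound 1 to compound 2: the two descriptions of the place agree word for word. Since that earlier step was at least modest and reached a limit, the expectation rests on it. Compound 4 is expected to show a 2.9-fold higher number from compound 3 to compound 4 (0.46 log units; beyond the scatter) in this assay, beside the earlier step of an at least 2.6-fold higher number from compound 1 to compound 2 (0.41 log units; beyond the scatter), and starting from the value of compound 3 this is expected to land beyond (the limit of > 20000 nM in this assay, at which 1 of the 3 values shown sits). The estimate for compound 4 in this assay is therefore 35000 nM, with a range from 18000 nM to 80000 nM, and most likely the assay will report only a limit.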

Compound 4, half-maximal inhibitory concentration: > 20000 nM
Compound 4: a limit, no number (the forecaster's own chance of this, stated with the estimate: 80%); the middle value does not contradict the limit.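

In this assay compound 4 gives only a limit of the assay, > 20000 nM, and not a number. With amino in place of hydrogen on an aromatic carbon, the record therefore reads as an at least 1.6-fold higher number from compound 3 to compound 4 (0.21 log units; that floor lies within the scatter), and the comparison with the earlier step on the other core can go no further than this: the same change on two cores in this assay, an at least 2.6-fold higher number (0.41 log units; beyond the scatter) from compound 1 to compound 2 and an at least 1.6-fold higher number (0.21 log units; that floor lies within the scatter) from compound 3 to compound 4; the limit leaves it open whether they differ. The result shows that the amino compound on each of the two cores ends at the limit of the assay, which fits the change carrying over, but it shows neither the size of the step on either core nor that the step on the second core exceeds the scatter, and the step between the two amino compounds cannot be read: the limit of > 20000 nM in this assay, at which 2 of the 4 values shown sit.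

The compounds shown leave open how far either amino compound lies past the limit, and so whether the choice between thiophen-2-yl and thiophen-3-yl still makes any difference once the amino group is present. They also leave open whether a methylamino group or a chlorine atom in that same place, between two ring nitrogen atoms, would give a readable number in this assay.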